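Sulfonamide series: aryl swap at the sulfonamide nitrogen

This account rests on a few compounds, and the source may have more. Where it says the series, first, only, none or still open, it means among the compounds named here.

Within the data shown here, in a functional assay on MCF7 cells (Homo sapiens) for antiproliferative activity, read by sulforhodamine B assay, with a stated time of 48 h (on this read-out lower numbers stand for stronger inhibition and higher numbers for weaker inhibition), compound 2 `COc1ccccc1NS(=O)(=O)c1ccc(N2CCNC2=O)cc1` gives 770 nM, the only measured number in the set. Compound 1 `O=C1NCCN1c1ccc(S(=O)(=O)Nc2ccc(C3CCCCC3)cc2)cc1` reaches only a limit, > 1000 nM, as noted in the limit of > 1000 nM in this assay, at which 1 of the 2 values shown sits. Compound 3 `Cc1ccc(NS(=O)(=O)c2ccc(N3CCNC3=O)cc2)cc1C` is not yet measured; the change from compound 2 is 3,4-dimethylphenyl in place of 2-methoxyphenyl on a sulfonamide nitrogen. Among the measured compounds shown here, no measured step covers such a change, so the expectation for compound 3 rests on compound 2 alone, and a step within the scatter or a modest loss is expected, a 1.1-fold higher number from compound 2 to compound 3 (0.04 log units; within the scatter). Compound 3 is therefore estimated at 850 nM, within 300 nM to 3000 nM.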

Compound 3, half-maximal inhibitory concentration: 230 nM
Compound 3: middle estimate off by 3.7-fold (0.57 log units), on the high side; measured number below the stated range.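

On a sulfonamide nitrogen, the aryl group does affect the read-out in this assay: 3,4-dimethylphenyl in place of 2-methoxyphenyl gives a 3.3-fold lower number from compound 2 to compound 3 (0.52 log units; beyond the scatter). The oxygen of 2-methoxyphenyl, the one hydrogen-bond acceptor in the leaving group, is therefore not required for activity in this pair. Nothing measured here accounts for the size of this step.

The pair does not separate losing the methoxy group from gaining the two methyl groups. From the compounds shown here alone, whether an amine or a carboxylic acid on this aryl group would keep the activity remains open.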